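Benzylsulfanyl exchange on the shared core: compound 4

This account rests on a few compounds, and the source may have more. Where it says the series, first, only, none or still open, it means among the compounds named here.

Compound 1 `Sc1nnc(-c2ccc3c(c2)OCCO3)n1-c1ccccc1` carries a hydrogen on the sulfur; in a functional assay on BGC-823 cells (Homo sapiens) for antiproliferative activity, read by MTT assay, with a stated time of 24 h (a lower number here means a stronger inhibitor, a higher number a weaker inhibitor), compound 1 gives 47000 nM. Compound 2 `Clc1cccc(CSc2nnc(-c3ccc4c(c3)OCCO4)n2-c2ccccc2)c1` carries 3-chlorobenzyl on that sulfur, and in this assay compound 2 gives 51200 nM. Of the two plain numbers, compound 2 has the highest, with compound 1 nearest: a 1.1-fold higher number from compound 1 to compound 2 (0.04 log units; within the scatter). Compound 3 `COc1cccc(CSc2nnc(-c3ccc4c(c3)OCCO4)n2-c2ccccc2)c1` carries 3-methoxybenzyl on the sulfur. In this assay compound 3 reaches only a limit, > 100000 nM, so no number is known for it; (the limit of > 100000 nM in this assay, at which 1 of the 3 values shown sits). The steps of an at least 2.1-fold higher number from compound 1 to compound 3 (0.32 log units; beyond the scatter) and an at least 1.9-fold higher number from compound 2 to compound 3 (0.29 log units; that floor lies within the scatter) are therefore floors rather than measured sizes.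

Compound 4 `Brc1ccc(CSc2nnc(-c3ccc4c(c3)OCCO4)n2-c2ccccc2)cc1` differs from compound 2 in one place: 4-bromophenyl in place of 3-chlorophenyl on a saturated chain carbon bound to a sulfur. The step bearing most directly on it is a 1.1-fold higher number from compound 1 to compound 2 (0.04 log units; within the scatter), which shows that putting 3-chlorobenzyl on the sulfur moved the number very little. The step of an at least 1.9-fold higher number from compound 2 to compound 3 (0.29 log units; that floor lies within the scatter) gives only a floor for exchanging one substituent on the benzyl ring for another. Nothing here points to a shift beyond the scatter for exchanging 3-chlorobenzyl for 4-bromobenzyl, so compound 4 is expected to show a 1.1-fold higher number from compound 2 to compound 4 (0.03 log units; within the scatter). In this assay compound 4 is estimated at 55000 nM, in a range from 25000 nM to 120000 nM, with a real chance that it is reported only as a limit.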

Compound 4, half-maximal inhibitory concentration: 33800 nM
For compound 4 the middle estimate is 1.6-fold (0.21 log units) above the measured one; the measured number falls inside the stated range.
By their numbers in this assay, from the lowest: compounds 4, 1 and 2 (each within the scatter of the next). At a limit, above all of these: compound 3.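

In this assay, 4-bromophenyl in place of 3-chlorophenyl on a saturated chain carbon bound to a sulfur gives a 1.5-fold lower number from compound 2 to compound 4 (0.18 log units; within the scatter), and 4-bromobenzyl in place of hydrogen on the sulfur gives a 1.4-fold lower number from compound 1 to compound 4 (0.14 log units; within the scatter). A second halogen-bearing benzyl group on the sulfur therefore also stays within the scatter of the parent with hydrogen on that sulfur, and among the compounds shown only compound 3, with 3-methoxybenzyl, goes against this pattern. The step of an at least 2.9-fold lower number from compound 3 to compound 4 (0.47 log units; beyond the scatter) is a floor that now clears the scatter, unlike the earlier floor from compound 2, and compound 3 itself remains a limit rather than a number: the limit of > 100000 nM in this assay, at which 1 of the 4 values shown sits.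

The exchange of 3-chlorobenzyl for 4-bromobenzyl alters the halogen and its ring position together, so the two changes cannot be read apart from these compounds. Going by these compounds, it stays open how an amine or a carboxylic acid on the benzyl ring, or a longer chain on the sulfur, would behave on the shared core.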